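From Pyridin-2-yl to Pyridin-4-yl on a Shared Core

The source may hold more compounds than are shown below. What is called first, only, known or untested is meant among the compounds shown, and "the series" means these compounds.

Within the data shown here, compound 1 `Nc1ccccc1NC(=O)c1ccc(CSC(=S)N2CCN(Cc3ccccn3)CC2)cc1` was tested in a functional assay on HeLa cells (Homo sapiens) for antiproliferative activity, read by CCK-8 assay, with a stated time of 72 h, tested at 2 uM (on this read-out higher numbers stand for a stronger effect at the one concentration tested and lower numbers for a weaker effect), and gives 14.2%, the lowest of the two numbers known here. In this assay compound 2 `Nc1ccccc1NC(=O)c1ccc(CSC(=S)N2CCc3cc(Cl)ccc32)cc1` gives 40.1%, a number that stands above compound 1 by more than the usual scatter. Compound 3 `Nc1ccccc1NC(=O)c1ccc(CSC(=S)N2CCN(Cc3ccncc3)CC2)cc1` has not been measured; it carries the same atoms as compound 1, joined differently, with the change (pyridin-4-yl in place of pyridin-2-yl on a saturated chain carbon bound to an amine nitrogen in a ring). Among the measured compounds shown here, no measured pair shows what this change does, so in this assay only a small step is expected, one likely to stay within the scatter, namely a number 3.8 percentage points higher from compound 1 to compound 3 (within the scatter). Compound 3 is therefore estimated at 18%, with a range from 5% to 35%.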

Compound 3, a percentage reported as inhibition, at one concentration (the size of the read-out at that concentration, not a potency): 59.5%
For compound 3 the middle estimate is 41.5 percentage points below the measured one, and the stated range ends below it.
By their numbers in this assay, from the lowest: compound 1; then compound 2; then compound 3.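

In this assay, putting pyridin-4-yl in place of pyridin-2-yl on a saturated chain carbon bound to an amine nitrogen in a ring gives a number 45.3 percentage points higher from compound 1 to compound 3 (beyond the scatter). This place on the shared core therefore responds strongly to how the pyridine ring is joined, even with the same atoms and the same counts of donors and acceptors. Nothing available here explains the step. As far as these compounds go, what pyridin-3-yl or a plain phenyl ring would give at this place remains open, as does the effect of a longer chain carrying pyridin-4-yl.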